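Dropping a Methyl and Shortening a Chain

The source may hold more compounds than are shown below. What is called first, only, known or untested is meant among the compounds shown, and "the series" means these compounds.

Compound 1 `CN1CCN(CCCN(C[C@H]2Cc3ccccc3CN2)[C@H]2CCCc3cccnc32)CC1` has the lowest reading of three compounds in an ADME assay on microsomes from liver (Rattus norvegicus) for metabolic stability, read by LC-MS, with a stated time of 10 min, tested at 0.5 uM (a higher number here means that more of the compound is left, a lower number that less of the compound is left), where compound 1 gives 10%. Compound 2 `c1ccc2c(c1)CN[C@H](CN(CCCN1CCNCC1)[C@H]1CCCc3cccnc31)C2` gives 88%, and compound 3 `c1cnc2c(c1)CCC[C@@H]2N(CCCN1CCNCC1)Cc1nc2ccccc2[nH]1` gives 29%. Within the data shown here, the only change recorded as a single step, a number 59 percentage points lower from compound 2 to compound 3 (beyond the scatter), touches a different part of the molecule and so bears little on the step at hand. Compound 4 `c1ccc2c(c1)CN[C@@H](CN(CCN1CCNCC1)[C@H]1CCCc3cccnc31)C2` differs from compound 1 in this way: piperazin-1-yl in place of (4-methylpiperazin-1-yl)methyl on a saturated chain carbon, two bonds along the chain from an amine nitrogen. Seen one bond further out, 3-(4-methylpiperazin-1-yl)propyl becomes 2-(piperazin-1-yl)ethyl. Among the measured compounds shown here, compound 4 thus carries the same piperazin-1-yl group as compound 2, on a shorter chain; compounds 1 and 2 differ in that group alone and lie far apart, although no single step between them is recorded. Compound 4 is therefore expected to show a large rise, a number 60 percentage points higher from compound 1 to compound 4 (beyond the scatter), to an estimated 70% with a range from 40% to 95%. This rests on compound 2, whose reading of 88% came with the same piperazin-1-yl group.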

Compound 4, percent of the compound remaining: 62%
For compound 4 the middle estimate is 8 percentage points above the measured one; low and high end bracket the measured number.
By their numbers in this assay, from the lowest: compound 1; then compound 3; then compound 4; then compound 2.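

Among these compounds, this is the first recorded step on this side chain, and it shows that the chain end strongly affects the reading in this assay: a number 52 percentage points higher from compound 1 to compound 4 (beyond the scatter). Read one bond further out, the step replaces 3-(4-methylpiperazin-1-yl)propyl with 2-(piperazin-1-yl)ethyl, so losing the methyl and shortening the chain come as one change, and the new group also carries a hydrogen-bond donor that the old one lacks. Nothing measured here explains the rise.

Going by these compounds, how much each part of the change contributes on its own remains open, and a compound with a 2-(4-methylpiperazin-1-yl)ethyl chain on the same core would help to separate them. Also open, on these data alone, is how a morpholine ring or a longer chain would read at this place.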